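Methyl on the imine carbon of the naphthylmethylthio analogue

A few compounds are considered here, and "the series" means these few. Any claim that something is new, unique, unknown or untested is made for them only; others in the source may bear on it.

Compound 3 `Cc1cc(S(=O)(=O)/N=C(\N)N/N=C/C#Cc2ccccc2)c(SCc2cccc3ccccc23)cc1Cl` gives 8000 nM in a functional assay on HeLa cells (Homo sapiens) for antiproliferative activity, read by MTT assay, with a stated time of 72 h (on this read-out lower numbers stand for stronger inhibition and higher numbers for weaker inhibition), the second highest of the three numbers measured. Its nearest neighbour is compound 1 `C/C(C#Cc1ccccc1)=N\N/C(N)=N/S(=O)(=O)c1cc(C)c(Cl)cc1SCc1ccccc1` at 6000 nM, a gap within the scatter; furthest is compound 2 `C/C(C#Cc1ccccc1)=N\N/C(N)=N/S(=O)(=O)c1cc(C)c(Cl)cc1SCc1ccccc1C` at 270000 nM, beyond the scatter. Compound 4 `C/C(C#Cc1ccccc1)=N\N/C(N)=N/S(=O)(=O)c1cc(C)c(Cl)cc1SCc1cccc2ccccc12` is not yet measured; it differs from compound 3 by a group of 11 heavy atoms (10 carbon, 1 nitrogen; one six-membered aromatic ring of carbon only) in place of a group of 10 heavy atoms (9 carbon, 1 nitrogen; one six-membered aromatic ring of carbon only), on an amine nitrogen, which amounts to a methyl replacing hydrogen on the imine carbon of the hydrazone.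

Going by the values given here, the only measured step of one change, a 45-fold higher number from compound 1 to compound 2 (1.65 log units; beyond the scatter), concerns a methyl added on an aromatic carbon of the benzylthio group, a different place, so it bears only loosely on this step. Compound 1 already carries the methyl on the imine carbon and sits within the scatter of compound 3, but compound 1 also differs in the thioether arm, so the methyl's effect is not isolated. No step beyond the scatter is therefore expected for compound 4, with the estimate no change at the digits printed from compound 3 to compound 4 (within the scatter) set near no change. Compound 4 is expected to give about 8000 nM in this assay, between 2000 nM and 40000 nM.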

Compound 4, half-maximal inhibitory concentration: 125000 nM
The estimate for compound 4 lay 16-fold (1.19 log units) below the measured number, outside the stated range (above it).
By their numbers in this assay, from the lowest: compounds 1 and 3 (each within the scatter of the next); then compound 4; then compound 2.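

In this assay, this position is not silent: the group of 11 heavy atoms in place of the group of 10 heavy atoms, on an amine nitrogen, a difference of one methyl, gives a 16-fold higher number from compound 3 to compound 4 (1.19 log units; beyond the scatter). With that group held constant, the arm on the sulfur also counts, with naphthalen-1-yl in place of phenyl giving a 21-fold higher number from compound 1 to compound 4 (1.32 log units; beyond the scatter) and naphthalen-1-yl in place of 2-methylphenyl giving a 2.2-fold lower number from compound 2 to compound 4 (0.33 log units; beyond the scatter). No measurement on hand accounts for these steps.

From the compounds shown here alone, it remains open whether the methyl carries the same penalty when the arm on the sulfur is phenyl or 2-methylphenyl rather than naphthalen-1-yl. Also open, going by these compounds, is how an ethyl or a cyclopropyl would behave in place of that methyl.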